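Permeability of a Piperidine Carboxamide Series

This account rests on a few compounds, and the source may have more. Where it says the series, first, only, none or still open, it means among the compounds named here.

Measured compounds:
- compound 1 `Cc1oc(-c2ccc(F)cc2)nc1CN1CCC(C(=O)NCCCN2C[C@H](C)C[C@H](C)C2)CC1`: "not determined" (no result reported)
- compound 2 `Cc1ccccc1-c1nc(CN2CCC(C(=O)NCCCN3CC4CCCC(C4)C3)CC2)c(C)o1`: 331 10^-6 cm/s
- compound 3 `Cc1cccc(Cl)c1-c1nc(CN2CCC(C(=O)NCCCN3CCC(C(C)C)CC3)CC2)c(C)o1`: "not determined" (no result reported)

The account follows compound 1 and its neighbour compound 4 `COc1cccc(Cl)c1-c1nc(CN2CCC(C(=O)NCCCN3C[C@H](C)C[C@H](C)C3)CC2)c(C)o1`, which has not yet been measured. In a physicochemical assay for permeability, using PAMPA (on this read-out higher numbers stand for higher permeability and lower numbers for lower permeability), compound 1 has no single number, and compound 3 likewise has no single number in this assay. The only figure at hand is that of compound 2, which in this assay gives 331 10^-6 cm/s. Among the measured compounds shown here, no step between two measured compounds is available, so no measured change can be quoted for the series.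

Compound 4 differs from compound 1 in one place: 2-chloro-6-methoxyphenyl in place of 4-fluorophenyl on an aromatic carbon. For the measured compounds named here, since compound 1 has no number in this assay, the size and direction of the step cannot be anchored on it; the expectation rests on the shared core and on the single figure of compound 2. Compound 4 is expected to give a permeability of about 300 10^-6 cm/s in this assay, within a range of 100 10^-6 cm/s to 800 10^-6 cm/s, with the step from compound 1 treated as undetermined rather than as a change beyond the scatter.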

Compound 4, apparent permeability: 51 10^-6 cm/s
Estimate against measurement, compound 4: 5.9-fold (0.77 log units) above; measured number outside the range, below it.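

Among the compounds shown here, compound 1 has no single number in this assay, so no step to compound 4 can be read. The compounds shown leave open what placing 2-chloro-6-methoxyphenyl in place of 4-fluorophenyl does to this read-out. Nothing at hand bears on the result of compound 4.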